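A few compounds are considered here, and "the series" means these few. Any claim that something is new, unique, unknown or untested is made for them only; others in the source may bear on it.

In a functional assay on MCF7 cells (Homo sapiens) for inhibition, read by MTT assay, with stated times of 18 h and 4 h (on this read-out higher numbers stand for weaker inhibition and lower numbers for stronger inhibition), compound 3 `CCCCCCCCOP(=O)(O)OCCSC(=S)N1CCCCCC1` gives 78000 nM, the higher of the two exact numbers, the other being compound 2 `CCCCCCCCOP(=O)(O)OCCSC(=S)N1CCCCC1` at 26000 nM. Compound 1 `CCCCCCCCCCCCCCCCOP(=O)(O)OCCSC(=S)N1CCCCCC1` gives > 100000 nM, which is a limit of the assay and not a number.

Compound 4 `CCCOP(=O)(O)OCCSC(=S)N1CCCCCC1` differs from compound 3 in its chain: hydrogen in place of pentyl on a saturated chain carbon, three bonds along the chain from an oxygen on an unsaturated carbon. In words, this is hydrogen in place of pentyl on a saturated chain carbon, three bonds along the chain from an oxygen on an unsaturated carbon.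

Among the compounds with values here, only one measured step alters this chain: an at least 1.2-fold lower number from compound 1 to compound 3 (0.10 log units; that floor lies within the scatter). That step rests on a limit, so it offers a floor and not a true size. The other step, a 3.0-fold higher number from compound 2 to compound 3 (0.48 log units; beyond the scatter), puts azepan-1-yl in place of piperidin-1-yl on a thiocarbonyl carbon, a different place, and so says little here.

With so little to go on, no change beyond the scatter is expected in this assay, and the estimated step is a 1.3-fold higher number from compound 3 to compound 4 (0.11 log units; within the scatter). Compound 4 is estimated at 100000 nM, with an expected range of 40000 nM to 250000 nM.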

Compound 4, half-maximal inhibitory concentration: 74000 nM
Compound 4: the middle estimate sits 1.4-fold (0.13 log units) above what was measured, within the range that was stated.
By their numbers in this assay, from the lowest: compound 2; then compounds 4 and 3 (each within the scatter of the next). At a limit, above all of these: compound 1.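

Going from octyl to propyl on this chain gives a 1.1-fold lower number from compound 3 to compound 4 (0.02 log units; within the scatter) in this assay. Within the data shown here, this is the first step at this position read between two exact numbers, whereas the earlier step on the chain offered only a floor. Within this pair, the chain can therefore lose pentyl with no change beyond the scatter, while the azepan-1-yl group stays in place.

Still open, from the compounds shown here alone, is whether the same holds with piperidin-1-yl on the thiocarbonyl carbon, or for a chain ending in an amine or a carboxylic acid. The true size of the step from the longer chain of compound 1 also stays unknown, since its value is a limit and not a number: the limit of > 100000 nM in this assay, at which 1 of the 4 values shown sits.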